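Removing One Fluorine from the Fused Ring of Compound 2

This account rests on a few compounds, and the source may have more. Where it says the series, first, only, none or still open, it means among the compounds named here.

Compound 1, `CCN(CC)CCCn1c(=O)c(=Cc2ccccc2O)s/c1=C1\C(=O)Nc2ccccc21`: in a functional assay on MDA-MB-231 cells (Homo sapiens) for inhibition, read by MTT assay, with a stated time of 72 h (on this read-out higher numbers stand for weaker inhibition and lower numbers for stronger inhibition), compound 1 gives > 200000 nM, which is a limit of the assay rather than a number.
Compound 2, `CCN(CC)CCCn1c(=O)c(=Cc2ccc(F)cc2F)s/c1=C1\C(=O)Nc2cc(F)ccc21`: in this assay compound 2 gives 2100 nM.

Compound 2 carries the only real number shown in this assay. Compound 1 sits at the limit of > 200000 nM in this assay, at which 1 of the 2 values shown sits. Compound 1 differs from compound 2 in more than one place. For the measured compounds named here, no single-change step between measured compounds is known here, and the two values say only that compound 2 inhibits at a measurable concentration while compound 1 does not within the assay's reach.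

Compound 3, `CCN(CC)CCCn1c(=O)c(=Cc2ccc(F)cc2F)s/c1=C1\C(=O)Nc2ccccc21`, differs from compound 2 in one place only: hydrogen in place of fluoro on an aromatic carbon of the six-membered aromatic ring of carbon only that is part of the fused two-ring system. Losing one fluorine in this position is a small change, so the expected step in this assay from compound 2 to compound 3 is small, if anything toward weaker inhibition, and may well stay within the usual scatter: a 1.7-fold higher number from compound 2 to compound 3 (0.22 log units; within the scatter). Compound 3 is therefore estimated at 3500 nM, with a likely range from 1200 nM to 10000 nM.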

Compound 3, half-maximal inhibitory concentration: > 200000 nM
Compound 3 gave a limit, no number; the forecaster's own chance of this, stated with the estimate: 10%; middle value at least 57-fold (1.75 log units) away from the limit.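

The fluorine on the fused ring is no minor detail in this series: in this assay, replacing it with hydrogen gives an at least 95-fold higher number from compound 2 to compound 3 (1.97 log units; beyond the scatter). This is the first single-change step among the compounds shown, so the loss of measurable inhibition can be traced to this one aromatic carbon of the fused two-ring system, with the 2,4-difluorophenyl group and the rest of the molecule unchanged. Compound 3 gives a limit of the assay and not a number, so the full size of the loss is unknown, and it sits at the same limit as compound 1: the limit of > 200000 nM in this assay, at which 2 of the 3 values shown sit.

As far as these compounds go, with both compounds at that limit, the step between compound 1 and compound 3 cannot be read, and the effect of 2,4-difluorophenyl against 2-hydroxyphenyl stays unknown while this fluorine is missing. From the compounds shown here alone, it also remains open whether inhibition depends on fluorine itself or would survive with another group on the same carbon, such as chlorine, a methoxy group or an amine.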